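Para-substituent swap on a dienone: fluoro to nitro

The compounds below may be only part of what the source reports. "The series", "measured", "known", "first", "only" and "open" are said of these compounds alone.

Measured compounds:
Compound 1, `CC1=C(/C=C/C(=O)/C=C/c2ccc(Br)cc2)C(C)(C)CCC1`: 88800 nM
Compound 2, `CC1=C(/C=C/C(=O)/C=C/c2ccc(F)cc2)C(C)(C)CCC1`: 32200 nM

Both compounds share the same core and differ only in the group on the distant aromatic ring. For the measured compounds named here, in a functional assay on HeLa cells (Homo sapiens) for cytotoxicity, read by sulforhodamine B assay, with a stated time of 48 h (a higher number here means a weaker inhibitor, a lower number a stronger inhibitor), compound 2 gives the lowest of the two numbers; its nearest neighbour is compound 1, and the step of a 2.8-fold lower number from compound 1 to compound 2 (0.44 log units; beyond the scatter) is the only measured step so far.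

Compound 3, `CC1=C(/C=C/C(=O)/C=C/c2ccc([N+](=O)[O-])cc2)C(C)(C)CCC1`, has not yet been measured. It differs from compound 2 by nitro in place of fluoro on an aromatic carbon. Going by the values given here, no measured step swaps fluoro for nitro, so the only guide is that changing the group at this position shifted this assay by a modest amount between the two halogens. A step of similar, modest size in either direction is therefore plausible, and the expected step of a 1.1-fold lower number from compound 2 to compound 3 (0.03 log units; within the scatter) is set near no change. Compound 3 is estimated at 30000 nM, with a range from 8000 nM to 110000 nM.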

Compound 3, half-maximal inhibitory concentration: 28700 nM
The estimate for compound 3 lay 1.0-fold (0.02 log units) above the measured number; the range from low to high includes it.
By their numbers in this assay, from the lowest: compounds 3 and 2 (each within the scatter of the next); then compound 1.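

In this assay the nitro group, with its three heavy atoms and two hydrogen-bond acceptors, cannot be told apart from the single fluoro atom at this aromatic carbon (a 1.1-fold lower number from compound 2 to compound 3 (0.05 log units; within the scatter)). Bromo is now the one group of the three that stands apart, as the swap to nitro gives a modest step (a 3.1-fold lower number from compound 1 to compound 3 (0.49 log units; beyond the scatter)) and so does the swap to fluoro. Nothing shown here bears on what lies behind this difference.

Going by these compounds, whether an amine, a carboxylic acid or a longer chain at this position would move the number beyond the scatter remains open. On these data alone, it is also open whether these swaps would give the same result from another place on the ring or with a change to the shared core.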